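The compounds below may be only part of what the source reports. "The series", "measured", "known", "first", "only" and "open" are said of these compounds alone.

The measured compounds in a functional assay with metabotropic glutamate receptor 5 (Rattus norvegicus) as the target; a lower number here means a stronger inhibitor, a higher number a weaker inhibitor:

compound 1, `N#Cc1cccc(-n2nnc(-c3ncc[nH]3)n2)c1`, gives 77 nM
compound 2, `N#Cc1cc(F)cc(-n2nnc(-c3ncc[nH]3)n2)c1`, gives 47 nM
compound 3, `N#Cc1cccc(-n2ccc(-c3ccccn3)c2)c1`, gives 190 nM

Compound 2 differs from compound 1 by one change, (fluoro in place of hydrogen on an aromatic carbon), and this change made the step of a 1.6-fold lower number from compound 1 to compound 2 (0.21 log units; within the scatter), so in this assay the two compounds cannot be told apart. Compound 3 has the highest number of the three; how its core differs from the core of compound 1 is not broken down here, and the two values simply show a weaker inhibitor in compound 3.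

Compound 4, `N#Cc1cc(F)cc(-n2ccc(-c3ccccn3)c2)c1`, has not yet been measured. It differs from compound 3 by fluoro in place of hydrogen on an aromatic carbon, the same change that leads from compound 1 to compound 2, placed in the same way. Because that earlier step was a 1.6-fold lower number from compound 1 to compound 2 (0.21 log units; within the scatter), compound 4 is expected to give a step of about a 1.6-fold lower number from compound 3 to compound 4 (0.20 log units; within the scatter), a small one. The estimate for compound 4 in this assay is therefore 120 nM, expected to lie between 50 nM and 300 nM.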

Compound 4, half-maximal inhibitory concentration: 3 nM
Compound 4: the middle estimate sits 40-fold (1.60 log units) above what was measured; measured number outside the range, below it.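

In this assay, fluoro in place of hydrogen on an aromatic carbon gives a 63-fold lower number from compound 3 to compound 4 (1.80 log units; beyond the scatter), a large step on this core. Carrying the change from one core to the other therefore did not carry the size of its step with it, as the two steps set side by side show: the same change on two cores in this assay, a 1.6-fold lower number (0.21 log units; within the scatter) from compound 1 to compound 2 and a 63-fold lower number (1.80 log units; beyond the scatter) from compound 3 to compound 4, 39-fold (1.59 log units) apart, beyond the scatter of two such steps These two pairs do not show which difference between the cores goes with the larger step, and they give no rule for what the same change would do on a third core.

The compounds shown leave open whether chloro, methyl or methoxy in the same place, meta to the cyano group, would give a large step on the core of compound 3 or a small one on the core of compound 1. They also leave open whether the large step on the core of compound 3 would persist if the cyano group gave way to a chloro group.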